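The compounds below may be only part of what the source reports. "The series", "measured", "known", "first", "only" and "open" are said of these compounds alone.

Measured in an ADME assay on HepG2 cells (Homo sapiens) for inhibition, read by fluorescence and resazurin assay, with a stated time of 72 h; a lower number here means a stronger inhibitor, a higher number a weaker inhibitor:
- compound 1 `Cc1cccc(Nc2nccc(Nc3ccc4cn[nH]c4c3)n2)c1`: 15000 nM
- compound 2 `Brc1cccc(Nc2nccc(Nc3ccc4cn[nH]c4c3)n2)c1`: 17000 nM
- compound 3 `CN1CCN(c2ccc(Nc3nccc(Nc4ccc5cn[nH]c5c4)n3)cc2)CC1`: 7000 nM

Compound 3 has the lowest number of the three, beyond the scatter from both others. Compound 4 `Cc1ccc(Nc2nccc(Nc3ccc4cn[nH]c4c3)n2)cc1` has not yet been measured. It carries methyl in place of 4-methylpiperazin-1-yl on an aromatic carbon. Going by the values given here, the one measured step, a 1.1-fold higher number from compound 1 to compound 2 (0.05 log units; within the scatter), exchanges methyl for bromo, lies within the scatter and does not touch the 4-methylpiperazin-1-yl. The closer guide is compound 1, which also carries methyl and has no 4-methylpiperazin-1-yl, at 15000 nM. A step to a higher number is therefore expected in this assay, and the expected step is a 2.0-fold higher number from compound 3 to compound 4 (0.30 log units; within the scatter). The estimated value for compound 4 is 14000 nM, with an expected range of 7500 nM to 28000 nM.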

Compound 4, half-maximal inhibitory concentration: 18000 nM
The estimate for compound 4 lay 1.3-fold (0.11 log units) below the measured number, within the range that was stated.
By their numbers in this assay, from the lowest: compound 3; then compounds 1, 2 and 4 (each within the scatter of the next).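

In this assay, going by these compounds alone, the exchange of 4-methylpiperazin-1-yl for methyl on the same aromatic carbon gives a 2.6-fold higher number from compound 3 to compound 4 (0.41 log units; beyond the scatter), the first single change here to go beyond the scatter. The 4-methylphenyl group, by contrast, is level with 3-methylphenyl and 3-bromophenyl, with a 1.2-fold higher number from compound 1 to compound 4 (0.08 log units; within the scatter) and a 1.1-fold higher number from compound 2 to compound 4 (0.02 log units; within the scatter). Nothing available explains the step at the 4-methylpiperazin-1-yl position.

The compounds shown do not tell whether the whole 4-methylpiperazin-1-yl group is needed for this step. A morpholine ring or a dimethylamino group at that place would bear on this.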